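A few compounds are considered here, and "the series" means these few. Any claim that something is new, unique, unknown or untested is made for them only; others in the source may bear on it.

Measured in a functional assay on HT-29 cells (Homo sapiens) for inhibition, read by MTT assay; a lower number here means a stronger inhibitor, a higher number a weaker inhibitor:
Compound 1 `COc1ccc2c(c1)CC[C@H](O)/C2=C/c1cc(OC)c(OC)c(OC)c1` gives 1 nM
Compound 2 `COc1ccc(/C=C2\c3cc(OC)c(OC)c(OC)c3CC[C@@H]2O)cc1N` gives 160 nM

Of these two compounds, compound 2 has the higher number and is the weaker inhibitor, with a gap to compound 1 that lies beyond the scatter. The next compound to be measured is compound 3 `COc1ccc(/C=C2\c3cc(OC)c(OC)c(OC)c3CC[C@@H]2O)cc1C`, which differs from compound 2 by methyl in place of amino on an aromatic carbon. In words, this is methyl in place of amino on an aromatic carbon, ortho to a methoxy group. Among the measured compounds shown here, no measured pair shows this change on its own, so the expectation has little support. For the measured compounds named here, the only close reference is compound 2 at 160 nM in this series. A modest rise in the number is expected, and the estimated change is a 2.5-fold higher number from compound 2 to compound 3 (0.40 log units; beyond the scatter) toward weaker inhibition. For compound 3 the estimate is 400 nM with an expected range of 60 nM to 2500 nM for this measurement.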

Compound 3, half-maximal inhibitory concentration: 2560 nM
For compound 3 the middle estimate is 6.4-fold (0.81 log units) below the measured one, outside the stated range (above it).
By their numbers in this assay, from the lowest: compound 1; then compound 2; then compound 3.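

In this assay, the aromatic carbon ortho to a methoxy group proves sensitive to the identity of a single heavy atom: methyl in place of amino gives a 16-fold higher number from compound 2 to compound 3 (1.20 log units; beyond the scatter). Of the two groups at this place, amino, with one hydrogen-bond donor and one acceptor, carries the lower number, and methyl, with neither, carries the higher, so the position does not treat these two groups as interchangeable. Nothing measured here explains the size or direction of this step.

One pair cannot separate the role of the hydrogen-bond count from other differences between amino and methyl; a hydroxy group, a methylamino group or a fluorine at the same place would test this. As far as these compounds go, whether the step carries over to the core of compound 1 also remains open.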